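Swapping Chloro for Methoxy on Compound 3

The compounds below may be only part of what the source reports. "The series", "measured", "known", "first", "only" and "open" are said of these compounds alone.

Measured so far in a functional assay on EC9706 cells (Homo sapiens) for cytotoxicity, read by MTT assay, with a stated time of 72 h; a higher number here means a weaker inhibitor, a lower number a stronger inhibitor:
Compound 1 `O=C(CSC(=S)N[C@H]1CCOC1=O)Nc1ccc(Cl)cc1` gives > 128000 nM, which is a limit and not a number.
Compound 2 `COc1ccc(NC(=O)CSC(=S)N[C@H]2CCOC2=O)cc1` gives > 128000 nM, likewise a limit and not a number.
Compound 3 `O=C(CCl)Nc1ccc(C(=O)/C=C/c2cccc(Cl)c2)cc1` gives 5560 nM.

Compound 1 and compound 2 share one core and differ only in methoxy in place of chloro on an aromatic carbon. Both values are limits, so the step that the two limits leave unreadable from compound 1 to compound 2; what stands behind it is the limit of > 128000 nM in this assay, at which 2 of the 3 values shown sit. Compound 3 is built on a different core, and the difference between the two cores is not broken down here. The unmeasured compound 4 `COc1cccc(/C=C/C(=O)c2ccc(NC(=O)CCl)cc2)c1` differs from compound 3 by methoxy in place of chloro on an aromatic carbon. This is the same kind of change as from compound 1 to compound 2, but not the same: there the group sits para to a large group, here meta to a large group. The measured example gives no readable size to lean on. On that footing the change is expected to stay small, and compound 4 is estimated at 6000 nM, meaning a 1.1-fold higher number from compound 3 to compound 4 (0.03 log units; within the scatter), with a plausible span from 2000 nM to 20000 nM.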

Compound 4, half-maximal inhibitory concentration: 5970 nM
Compound 4: the middle estimate sits 1.0-fold (0.00 log units) above what was measured; the range from low to high includes it.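

In this assay, methoxy in place of chloro on an aromatic carbon, meta to a large group, gives a 1.1-fold higher number from compound 3 to compound 4 (0.03 log units; within the scatter), so on this core the two groups cannot be told apart by this read-out. That is a single pair on a single core, and it does not show that the swap would behave the same way on another core, or with the group at another place on the ring. The same swap on the core of compound 1 gives a step that cannot be read, which leaves no second size to set beside this one: the limit of > 128000 nM in this assay, at which 2 of the 4 values shown sit.

The compounds shown leave open whether a different group at this place on the core of compound 3, such as an amine or a carboxylic acid, would move the number beyond the scatter. They also leave open whether a longer chain on the oxygen, such as ethoxy, would keep the number where methoxy has it.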